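Methoxy Placement on Two Pyrazoline Carbamates

The source may report more compounds than this note shows. Statements on the series, on what has been measured and on what is new or still open speak of the compounds shown alone.

Three compounds were measured in a functional assay on MDA-MB-231 cells (Homo sapiens) for antiproliferative activity, read by MTT assay, with a stated time of 48 h; on this read-out higher numbers stand for weaker inhibition of growth and lower numbers for stronger inhibition of growth. Compound 1 `CCCOC(=O)N1N=C(c2ccccc2)CC1c1cc(OC)c(OC)c(OC)c1` gives 14400 nM, compound 2 `CCCOC(=O)N1N=C(c2ccc(OC)cc2)CC1c1cc(OC)c(OC)c(OC)c1` gives 20400 nM, and compound 3 `COC(=O)N1N=C(c2ccccc2)CC1c1ccc(OC)c(OC)c1` gives 8940 nM. Compound 2 differs from compound 1 by methoxy in place of hydrogen on an aromatic carbon, and that change made a 1.4-fold higher number from compound 1 to compound 2 (0.15 log units; within the scatter). Compound 4 `COC(=O)N1N=C(c2ccccc2)CC1c1cc(OC)c(OC)cc1OC` has not yet been measured; it differs from compound 3 by methoxy in place of hydrogen on an aromatic carbon. The difference between the cores of compound 1 and compound 3 is not broken down here. The change into compound 4 is the same kind of change as that into compound 2, but the place differs: in compound 2 the methoxy enters para to a large group, whereas in compound 4 it enters ortho to a large group, meta to a methoxy group and para to a methoxy group. Because the earlier change gave a 1.4-fold higher number from compound 1 to compound 2 (0.15 log units; within the scatter), a similar small step is expected, a 1.3-fold higher number from compound 3 to compound 4 (0.13 log units; within the scatter), so compound 4 is estimated at 12000 nM in this assay, with a range from 5000 nM to 30000 nM.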

Compound 4, concentration for 50% growth inhibition: > 10000 nM
Compound 4: no number, only a limit; the forecaster's own chance of this, stated with the estimate: 10%; the middle value does not contradict the limit.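

In this assay compound 4 gives > 10000 nM, which is a limit of the assay and not a number. Methoxy in place of hydrogen on an aromatic carbon thus gives an at least 1.1-fold higher number from compound 3 to compound 4 (0.04 log units; that floor lies within the scatter), and that figure is only a floor on the true step. Set beside the earlier step, this does not show whether the change carries over from one core to the other with the same size: the same change on two cores in this assay, a 1.4-fold higher number (0.15 log units; within the scatter) from compound 1 to compound 2 and an at least 1.1-fold higher number (0.04 log units; that floor lies within the scatter) from compound 3 to compound 4; the limit leaves it open whether they differ

The compounds shown leave open how an amine or a carboxylic acid would read in place of this methoxy on the aromatic ring. They also leave open how a butyl chain on the carbamate would read on either core.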